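Pyrrolidinyl Replaces Cyclohexylamino on the Shared Core

The source may report more compounds than this note shows. Statements on the series, on what has been measured and on what is new or still open speak of the compounds shown alone.

Among the compounds with values here, compound 2 `NC(N)=NC(=O)c1nc(Cl)c(NC2CCCCC2)nc1N` stands highest of the two numbers so far in an assay for inhibition of acid-sensing ion channel 3 (Homo sapiens), read by patch clamp, tested at 1 uM (a lower number here means less inhibition, a higher number more inhibition at the concentration tested (going by the name of the read-out)), where compound 2 gives 21%. Its nearest neighbour is compound 1 `C=CCNc1nc(N)c(C(=O)N=C(N)N)nc1Cl`, which in this assay gives 16%. The step of a number 5 percentage points higher from compound 1 to compound 2 (within the scatter) lies within the scatter, so the two values show no real separation. Within the data shown here, that step, cyclohexyl in place of allyl on a nitrogen on an aromatic ring, is the only measured step and the only one that bears on the change now considered.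

Compound 3 `NC(N)=NC(=O)c1nc(Cl)c(N2CCCC2)nc1N` differs from compound 2 as follows: pyrrolidin-1-yl in place of cyclohexylamino on an aromatic carbon. Both the measured step and this one exchange the group on the same aromatic carbon of the shared core, though here the secondary amine itself is replaced by a ring nitrogen. Among the measured compounds shown here, with the one relevant step having stayed within the scatter, no movement beyond the scatter is expected in this assay. The step of a number 3 percentage points lower from compound 2 to compound 3 (within the scatter) is estimated to be small. Compound 3 is therefore expected to give about 18% in this assay, with a likely range from 5% to 32%.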

Compound 3, a percentage reported as inhibition, at one concentration (the size of the read-out at that concentration, not a potency): 12%
The estimate for compound 3 lay 6 percentage points above the measured number; low and high end bracket the measured number.
By their numbers in this assay, from the lowest: compounds 3, 1 and 2 (each within the scatter of the next).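

In this assay, exchanging cyclohexylamino for pyrrolidin-1-yl gives a number 9 percentage points lower from compound 2 to compound 3 (within the scatter), and exchanging allylamino for pyrrolidin-1-yl gives a number 4 percentage points lower from compound 1 to compound 3 (within the scatter). This is the first change at this aromatic carbon to remove the hydrogen-bond donor on the attached nitrogen: the groups in compound 1 and compound 2 both carry one, while pyrrolidin-1-yl in compound 3 has none, and neither step leaves the scatter, so at this concentration the compounds shown give no sign that the donor matters. No measurement at hand accounts for these numbers.

Going by these compounds, since the allylamino, cyclohexylamino and pyrrolidin-1-yl compounds all lie within the scatter of one another, it remains open whether any group on this carbon can separate from them, such as a longer alkyl chain, a benzylamino group or a carboxylic acid. The chloro group and the amino group stay the same throughout, so these compounds also leave open what a bromo group in place of the chloro group, or an acetamido group in place of the amino group, would do in this assay.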